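This account rests on a few compounds, and the source may have more. Where it says the series, first, only, none or still open, it means among the compounds named here.

Compound 1 `Cn1c(/C=C/C(=O)c2ccc[nH]2)cc(Br)c1Br` and compound 2 `O=C(/C=C/c1cc(Br)c(Br)[nH]1)c1ccc[nH]1` share one core and differ in a single place: hydrogen in place of methyl on an aromatic nitrogen. In a functional assay on MCF7 cells (Homo sapiens) for cytotoxicity, read by MTT assay, with stated times of 6 h and 48 h (a higher number here means a weaker inhibitor, a lower number a stronger inhibitor), compound 1 gives 450 nM, while compound 2 gives 72 nM, so that a 6.3-fold lower number from compound 1 to compound 2 (0.80 log units; beyond the scatter). Compound 3 `Cn1c(-c2cc(-c3ccccc3O)no2)cc(Br)c1Br` has a different core; how it differs from that of compound 1 is not broken down here. In this assay compound 3 gives only a limit, >= 100000 nM, and so sits at the limit of >= 100000 nM in this assay, at which 1 of the 3 values shown sits. Compound 4 `Oc1ccccc1-c1cc(-c2cc(Br)c(Br)[nH]2)on1` has not yet been measured; it differs from compound 3 by hydrogen in place of methyl on an aromatic nitrogen. The place matches the earlier change except that there the neighbouring ring atom bears a group of 9 heavy atoms and here a large group, so this is the same kind of change rather than the same one. For compound 4 a step of about an at least 2.0-fold lower number from compound 3 to compound 4 (0.30 log units; that floor lies within the scatter) is expected, resting on a 6.3-fold lower number from compound 1 to compound 2 (0.80 log units; beyond the scatter) and on compound 3 standing at the limit of >= 100000 nM in this assay, at which 1 of the 3 values shown sits. Compound 4 is therefore estimated at 50000 nM.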

Compound 4, half-maximal inhibitory concentration: >= 100000 nM
Compound 4: a limit, no number; the forecaster's own chance of this, stated with the estimate: 55%; middle value at least 2.0-fold (0.30 log units) from the limit.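

Compound 3 and compound 4 each give only a limit, not a number, so no step between them can be read: the limit of >= 100000 nM in this assay, at which 2 of the 4 values shown sit.

Still open, as far as these compounds go, is whether hydrogen in place of methyl on the aromatic nitrogen changes activity on this core at all.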